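The source may report more compounds than this note shows. Statements on the series, on what has been measured and on what is new or still open speak of the compounds shown alone.

The measured compounds in an assay on HEK293 cells for displacement of a labelled ligand from Type-2 angiotensin II receptor (Homo sapiens); on this read-out lower numbers stand for stronger inhibition and higher numbers for weaker inhibition:

Compound 1, `CC[C@H](C)[C@H](NC(=O)c1cccc(Cn2ccnc2)c1)C(=O)NNS(=O)(=O)c1ccccc1`: > 100000 nM, a limit of the assay rather than a number.
Compound 2, `CC[C@H](C)[C@H](NC(=O)c1cccc(Cn2ccnc2)c1)C(=O)NS(=O)(=O)c1ccccc1`: 18000 nM.
Compound 3, `CCCCS(=O)(=O)NNC(=O)[C@@H](NC(=O)c1cccc(Cn2ccnc2)c1)[C@@H](C)CC`: > 100000 nM, a limit of the assay rather than a number.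

Compound 1 stands at the limit of > 100000 nM in this assay, at which 2 of the 3 values shown sit, so only a limit is known for it. Compound 4, `CC[C@H](C)[C@H](NC(=O)c1cccc(Cn2ccnc2)c1)C(=O)NNC(=O)OC(C)(C)C`, differs from compound 1 as follows: tert-butoxycarbonyl in place of phenylsulfonyl on an amine nitrogen. Among the compounds with values here, no measured step covers this change. Within the data shown here, the one readable step, an at least 5.5-fold lower number from compound 1 to compound 2 (0.74 log units; beyond the scatter), concerns phenylsulfonyl in place of (phenylsulfonyl)amino on an amide-type nitrogen, a different alteration. The step that the two limits leave unreadable from compound 1 to compound 3, butyl in place of phenyl on a sulfonyl sulfur, keeps the (sulfonyl)amino arrangement that compound 4 also retains, but both of its ends sit at the limit and its size cannot be read. Compound 1 and compound 3, the two compounds with this arrangement, are both at the limit. The expectation for compound 4 is therefore no step beyond the scatter, a number no higher from compound 1 to compound 4 (the limit leaves the size open), with a limit again the most likely report. The estimate for compound 4 is 100000 nM, in a range from 30000 nM to 300000 nM.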

Compound 4, inhibition constant: > 100000 nM
Compound 4 was reported as a limit; the forecaster's own chance of this, stated with the estimate: 75%; the middle value sits exactly at the limit.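

Compound 4 is also reported in this assay only as a limit of the assay, not as a number: the limit of > 100000 nM in this assay, at which 3 of the 4 values shown sit.

On the amine nitrogen, tert-butoxycarbonyl, which has no ring, therefore ends at the same limit as phenylsulfonyl in compound 1 and butylsulfonyl in compound 3, and the steps among these three cannot be read. Within the data shown here, the only number still belongs to the compound without the extra amino nitrogen, and this carbamate-bearing variant gives an at least 5.5-fold higher number from compound 2 to compound 4 (0.74 log units; beyond the scatter).

No order among these three groups on the amine nitrogen can be given from limits alone. On these data alone, it also remains open whether a free amine or an acetyl group at this place would give a readable number.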